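Phenyl in place of benzyl: half-life notes on the series

The compounds below may be only part of what the source reports. "The series", "measured", "known", "first", "only" and "open" are said of these compounds alone.

Of the compounds shown here, two sharing one core have been read so far in a physicochemical assay for pharmacokinetics; on this read-out higher numbers stand for a longer-lived compound and lower numbers for a shorter-lived compound: compound 1 (`O=C(c1ccccc1)N1C(=O)c2ccccc2S1(=O)=O`) and compound 2 (`O=C(OCc1ccccc1)N1C(=O)c2ccccc2S1(=O)=O`). Compound 1 gives > 166 h as its reading, which is a limit of the assay and not a number. Compound 2 gives > 166 h as its reading, which is likewise a limit. Compound 2 therefore stands at the limit of > 166 h in this assay, at which 2 of the 2 values shown sit, and has no number of its own, and no order can be told between the two compounds.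

Compound 3 (`O=C(Oc1ccccc1)N1C(=O)c2ccccc2S1(=O)=O`) differs from compound 2 in one place, with phenyl in place of benzyl on an oxygen next to a carbonyl group. Going by the values given here, no measured step gives a size for this change, so the expectation rests on the structural change alone. The expected move is an at least 1.3-fold lower number from compound 2 to compound 3 (0.14 log units; that floor lies within the scatter) in this assay and points modestly toward a shorter-lived compound, probably not beyond the scatter. A further reading at the limit remains quite possible. For compound 3 the estimated half-life is 120 h (expected range 30 h to 400 h).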

Compound 3, half-life: > 166 h
Compound 3: a limit, no number (the forecaster's own chance of this, stated with the estimate: 50%); at least 1.3-fold (0.14 log units) between middle value and limit.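

Going by these compounds alone, compound 3 gives a limit and not a number in this assay, as do compound 1 and compound 2, so no step from either of them to compound 3 can be read. All three sit at one reading: the limit of > 166 h in this assay, at which 3 of the 3 values shown sit.

The compounds shown leave open how the half-lives of these three compare, including whether phenyl in place of benzyl shifts the half-life at all.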